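Aryl swap on the pyrazolyl-pyrimidinone series: compound 3

The source may hold more compounds than are shown below. What is called first, only, known or untested is meant among the compounds shown, and "the series" means these compounds.

Two members have been measured. Compound 1 `CCOC(=O)c1cnn(-c2nc(-c3ccccc3F)c(C#N)c(=O)n2C)c1N` gives 86 ug/mL in a functional assay, with a stated time of 10 min; on this read-out higher numbers stand for weaker inhibition and lower numbers for stronger inhibition. Compound 2 `CCOC(=O)c1cnn(-c2nc(-c3cccc(OC)c3OC)c(C#N)c(=O)n2C)c1N` sits at 67 ug/mL in this assay; the step of a 1.3-fold lower number from compound 1 to compound 2 (0.11 log units; within the scatter) shows the two numbers side by side within the scatter. Compound 3 `CCOC(=O)c1cnn(-c2nc(-c3ccc(N(C)C)cc3)c(C#N)c(=O)n2C)c1N` carries 4-(dimethylamino)phenyl in place of 2,3-dimethoxyphenyl on an aromatic carbon. Among the compounds with values here, the only measured step that bears on it is the aryl exchange from compound 1 to compound 2, which stayed within the scatter, so the aryl group has not yet moved this assay beyond the scatter and no step beyond it is expected here. The step that is expected is a 1.0-fold higher number from compound 2 to compound 3 (0.02 log units; within the scatter). Compound 3 is estimated at 70 ug/mL, between 35 ug/mL and 140 ug/mL.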

Compound 3, half-maximal inhibitory concentration: 119 ug/mL
Compound 3: the middle estimate sits 1.7-fold (0.23 log units) below what was measured; measured number inside the range.
By their numbers in this assay, from the lowest: compounds 2, 1 and 3 (each within the scatter of the next).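

In this assay, 4-(dimethylamino)phenyl at this position stays within the scatter of both earlier aryl groups (a 1.8-fold higher number from compound 2 to compound 3 (0.25 log units; within the scatter); a 1.4-fold higher number from compound 1 to compound 3 (0.14 log units; within the scatter)). The series now holds three differently substituted phenyl groups here, including one carrying nitrogen rather than fluorine or oxygen, and none is separated from another beyond the scatter. No supporting data bear on why these numbers stay so close.

From the compounds shown here alone, whether an aryl replacement such as pyridyl or cyclohexyl would move the number beyond the scatter remains open. So does the response to a carboxylic acid in place of the ethyl ester.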